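A Methoxy for a Methyl at the Cytotoxicity Limit

The compounds below may be only part of what the source reports. "The series", "measured", "known", "first", "only" and "open" are said of these compounds alone.

Compound 2 `Cc1ccc(-c2nc3ccccc3s2)cc1NC(=O)c1cc([N+](=O)[O-])c(N2CCC(C(=O)O)CC2)cc1Cl` carries a carboxy on a saturated ring carbon, where compound 1 `Cc1ccc(-c2nc3ccccc3s2)cc1NC(=O)c1cc([N+](=O)[O-])c(N2CCCCC2)cc1Cl` has hydrogen. In an ADME assay on BJ cells (Homo sapiens) for cytotoxicity, with a stated time of 72 h (on this read-out lower numbers stand for an effect already at smaller amounts and higher numbers for an effect only at larger amounts of compound), compound 1 gives > 25000 nM, which is a limit of the assay and not a number. In this assay compound 2 gives > 25000 nM, again a limit rather than a measured value. The step that the two limits leave unreadable from compound 1 to compound 2 is therefore unreadable, since both values sit at the limit of > 25000 nM in this assay, at which 2 of the 2 values shown sit. Going by these compounds, compound 2 thus stands at the limit, and how far beyond it the true number lies is unknown.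

Compound 3 `COc1ccc(-c2nc3ccccc3s2)cc1NC(=O)c1cc([N+](=O)[O-])c(N2CCC(C(=O)O)CC2)cc1Cl` differs from compound 2 in one place: methoxy in place of methyl on an aromatic carbon The methyl leaves and a methoxy enters on the same aromatic carbon.

Among the measured compounds shown here, no measured step involves a change of this kind, and the single measured step is itself unreadable, so there is nothing that points to a shift in either direction. The expectation is that the change from compound 2 to compound 3 amounts to a step that the limit leaves unreadable from compound 2 to compound 3, no step beyond the scatter. Compound 3 is therefore estimated at 35000 nM, within a range from 12000 nM to 120000 nM, and most likely this assay will again report only a limit for compound 3.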

Compound 3, half-maximal effective concentration in the BJ assay: > 25000 nM
Compound 3 gave a limit, no number (the forecaster's own chance of this, stated with the estimate: 85%); the middle value does not contradict the limit.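

No step can be read from compound 2 to compound 3 in the BJ assay, since each gives only a limit of the assay and not a number: the limit of > 25000 nM in the BJ assay, at which 3 of the 3 values shown sit.

In a physicochemical assay for solubility, read by spectrophotometry, in phosphate buffer, measured as kinetic solubility, with a stated time of 18 h, at pH 7.4 (a higher number here means a more soluble compound, a lower number a less soluble compound), compound 2 gives 590 nM and compound 3 gives 210 nM.

The compounds shown leave open how far past the limit in the BJ assay the true numbers of compound 2 and compound 3 lie, and whether they differ at all.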